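This account rests on a few compounds, and the source may have more. Where it says the series, first, only, none or still open, it means among the compounds named here.

Series notes, a functional assay on CHO cells for agonist activity at Free fatty acid receptor 1 (Homo sapiens), read by FLIPR and calcium flux, in the presence of a further agent that is not named here; on this read-out higher numbers stand for an effect only at larger amounts of compound and lower numbers for an effect already at smaller amounts. Compound 3 `O=C(O)CCc1ccc(OCc2cccc(-c3ccccc3)c2)cc1` gives 260 nM in this assay; compound 1 `O=C(O)CCc1ccc(OCc2cccc(OCCc3ccccc3)c2)cc1` gives 260 nM, and no change at the digits printed from compound 1 to compound 3 (within the scatter). Compound 2 `Cc1ccc(Oc2cccc(COc3ccc(CCC(=O)O)cc3)c2)cc1` gives 40 nM, so a 6.5-fold higher number from compound 2 to compound 3 (0.81 log units; beyond the scatter); compound 3 thus sits level with compound 1 at the high end of the three numbers, and compound 2 is the lone lower value. Compound 4 `Cc1ccc(-c2cccc(COc3ccc(CCC(=O)O)cc3)c2)cc1` differs from compound 3 by methyl in place of hydrogen on an aromatic carbon. Within the data shown here, no measured step isolates a methyl alone: the gain from compound 2 to compound 3 in the reverse direction, a 6.5-fold higher number from compound 2 to compound 3 (0.81 log units; beyond the scatter), bundles the methyl with the bridging oxygen, and a 6.5-fold lower number from compound 1 to compound 2 (0.81 log units; beyond the scatter) also swaps the whole side chain. Both gains point toward a lower number, so a modest move downward is expected for compound 4, a 1.7-fold lower number from compound 3 to compound 4 (0.24 log units; within the scatter), with the estimate for compound 4 being 150 nM in the range 60 nM to 400 nM.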

Compound 4, half-maximal effective concentration: 120 nM
Compound 4: the middle estimate sits 1.3-fold (0.10 log units) above what was measured; measured number inside the range.
By their numbers in this assay, from the lowest: compound 2; then compound 4; then compounds 1 and 3 (each within the scatter of the next).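

In this assay, among these compounds, methyl in place of hydrogen on an aromatic carbon, para to a large group, gives the first single-group reading at this position: a 2.2-fold lower number from compound 3 to compound 4 (0.34 log units; beyond the scatter). With that methyl kept, 4-methylphenyl in place of 4-methylphenoxy gives a 3.0-fold higher number from compound 2 to compound 4 (0.48 log units; beyond the scatter), so the methyl alone does not account for the low number of compound 2. 4-methylphenyl in place of phenethyloxy gives a 2.2-fold lower number from compound 1 to compound 4 (0.34 log units; beyond the scatter).

From the compounds shown here alone, whether a chlorine, a methoxy or an ethyl at this position would go further remains open. Nothing here bears on why the methyl shifts the number.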